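This account rests on a few compounds, and the source may have more. Where it says the series, first, only, none or still open, it means among the compounds named here.

Compound 1 `CCC(CC)C(=O)Nc1c(C(O)(C(F)(F)F)C(F)(F)F)ccc2ccccc12` gives 4340 nM in an assay on LtK cells with ATP-sensitive inward rectifier potassium channel 11 (Homo sapiens) as the target; a higher number here means that more compound is needed for the effect, a lower number that less compound is needed.
Compound 2 `O=C(CC1CCCC1)Nc1c(C(O)(C(F)(F)F)C(F)(F)F)ccc2ccccc12` gives 81 nM.
Compound 3 `COCC(=O)Nc1c(C(O)(C(F)(F)F)C(F)(F)F)ccc2ccccc12` gives 213 nM.

Among these three, compound 3 stands second highest: the nearest number is that of compound 2, a 2.6-fold higher number from compound 2 to compound 3 (0.42 log units; beyond the scatter) apart, and the furthest that of compound 1, a 20-fold lower number from compound 1 to compound 3 (1.31 log units; beyond the scatter) apart. Every measured step changes only the group on the carbonyl carbon of the amide. Going from compound 1 to the others, the number fell sharply: a 54-fold lower number from compound 1 to compound 2 (1.73 log units; beyond the scatter) and a 20-fold lower number from compound 1 to compound 3 (1.31 log units; beyond the scatter). The remaining step, a 2.6-fold higher number from compound 2 to compound 3 (0.42 log units; beyond the scatter), is modest.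

Compound 4 `COc1cccc(C(=O)Nc2c(C(O)(C(F)(F)F)C(F)(F)F)ccc3ccccc23)c1` differs from compound 3 in one place: 3-methoxyphenyl in place of methoxymethyl on a carbonyl carbon. For the measured compounds named here, none of the measured steps puts a six-membered aromatic ring on the carbonyl carbon, so the guide is indirect. The three measured groups at this position span a wide range, with the cyclopentylmethyl of compound 2 giving the lowest number and the pentan-3-yl of compound 1 the highest. A modest step is expected, with a lower number somewhat more likely than a higher one: a 1.4-fold lower number from compound 3 to compound 4 (0.15 log units; within the scatter). Compound 4 is therefore estimated at 150 nM, within a range from 40 nM to 600 nM.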

Compound 4, half-maximal effective concentration: 185 nM
For compound 4 the middle estimate is 1.2-fold (0.09 log units) below the measured one; low and high end bracket the measured number.
By their numbers in this assay, from the lowest: compound 2; then compounds 4 and 3 (each within the scatter of the next); then compound 1.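

In this assay, replacing an open chain with a six-membered aromatic ring at this position leaves the number within the scatter: a 1.2-fold lower number from compound 3 to compound 4 (0.06 log units; within the scatter). The carbonyl carbon therefore tolerates the 3-methoxyphenyl group, a much larger substituent with a ring, as well as it tolerates methoxymethyl, although the cyclopentylmethyl group still holds a clear edge, with a 2.3-fold higher number from compound 2 to compound 4 (0.36 log units; beyond the scatter). The pentan-3-yl group remains the clear outlier among the four, as a 23-fold lower number from compound 1 to compound 4 (1.37 log units; beyond the scatter) adds a third group that gives a far lower number, and no measurement here explains these differences.

From the compounds shown here alone, what a plain phenyl group or a pyridine ring would give at this position stays open. So does the contribution of the methoxy group on the ring of compound 4.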